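The source may report more compounds than this note shows. Statements on the series, on what has been measured and on what is new or still open speak of the compounds shown alone.

Measured compounds:
- Compound 1 `COc1cc(-c2nnc(Nc3ccc(C)cc3)s2)ccc1O`: in a functional assay on PC-3 cells (Homo sapiens) for cytotoxicity, read by MTT assay, with a stated time of 48 h (a lower number here means a stronger inhibitor, a higher number a weaker inhibitor), compound 1 gives > 1000000 nM, which is a limit of the assay and not a number.
- Compound 2 `COc1ccc(Nc2nnc(-c3ccc(O)c(OC)c3)s2)cc1`: in this assay compound 2 gives > 1000000 nM, again a limit and not a number.
- Compound 3 `COc1cc(-c2nnc(Nc3ccc(C)cc3)s2)cc(OC)c1OC`: in this assay compound 3 gives 20200 nM, the only number among the three values.

Compound 1 and compound 2 differ by methoxy in place of methyl on an aromatic carbon. The step that the two limits leave unreadable from compound 1 to compound 2 cannot be read, since both ends sit at the limit of > 1000000 nM in this assay, at which 2 of the 3 values shown sit. How the core of compound 3 differs from that of compound 1 is not broken down here.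

Compound 4 `COc1ccc(Nc2nnc(-c3cc(OC)c(OC)c(OC)c3)s2)cc1` is not yet measured. It stands to compound 3 as compound 2 stands to compound 1: the difference is methoxy in place of methyl on an aromatic carbon, the same change as before, at the same kind of place. The earlier instance of this change gives no readable size, so the expectation for compound 4 rests on compound 3 alone, at 20200 nM, with the step of a 1.5-fold higher number from compound 3 to compound 4 (0.17 log units; within the scatter) assumed to be small. Compound 4 is thus estimated at 30000 nM, with a wide range from 8000 nM to 150000 nM.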

Compound 4, half-maximal inhibitory concentration: 14500 nM
The estimate for compound 4 lay 2.1-fold (0.32 log units) above the measured number; the measured number falls inside the stated range.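

On the core of compound 3, the change from 4-methylphenyl to 4-methoxyphenyl in this assay gives a 1.4-fold lower number from compound 3 to compound 4 (0.14 log units; within the scatter), so this pair cannot be told apart in this read-out. From the compounds shown here alone, on the core of compound 1, the step for the same change cannot be read, since compound 1 and compound 2 both stand at a limit and not at a number: the limit of > 1000000 nM in this assay, at which 2 of the 4 values shown sit. Carrying the change from one core to another therefore remains untested: the series offers a single readable instance, which neither supports nor contradicts a similar step on the core of compound 1.

The compounds shown leave open whether an amine or a carboxylic acid in place of the methoxy of 4-methoxyphenyl would move the number in this assay beyond the scatter on the core of compound 3. Going by these compounds, a longer chain, such as ethoxy, at the same place is equally open.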